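The source may report more compounds than this note shows. Statements on the series, on what has been measured and on what is new or still open speak of the compounds shown alone.

In an ADME assay on a cell-free system (plasma, Mus musculus) for protein binding, using equilibrium dialysis, compound 1 (`CC(C)c1coc(-c2cccc(CNc3ccc4[nH]nc(C(=O)O)c4c3)c2O)n1`) gives > 99.7%, which is a limit of the assay and not a number. Compound 4 (`Cc1nc(-c2cccc(CNc3ccc4[nH]nc(C(=O)O)c4c3)c2O)sc1C`) keeps the shared core but carries 4,5-dimethyl-1,3-thiazol-2-yl in place of 4-isopropyl-1,3-oxazol-2-yl on an aromatic carbon. Among the compounds with values here, no measured step makes this exchange. Compound 2 (`CN(C)c1noc(-c2cccc(CNc3ccc4[nH]nc(C(=O)O)c4c3)c2)n1`) gives 99%, and compound 3 (`CN(C)c1noc(-c2cccc(CNc3ccc4[nH]nc(C(=O)O)c4c3)c2Cl)n1`) gives 99.4%. Within the data shown here, the only measured step, a 1.7-fold lower unbound fraction from compound 2 to compound 3 (0.22 log units; within the scatter), is chloro in place of hydrogen on an aromatic carbon, so it bears on this exchange only loosely. With that step inside the scatter, no change beyond the scatter is expected, and the estimated size is an at least 1.3-fold higher unbound fraction from compound 1 to compound 4 (0.12 log units; that floor lies within the scatter). For compound 4, the expected value is 99.6%, with an estimated range of 99% to 99.9%.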

Compound 4, plasma protein binding in the Mus musculus assay: > 99.8%
Compound 4: no number, only a limit; the forecaster's own chance of this, stated with the estimate: 40%; at least 2.0-fold (0.30 log units) (unbound fraction) between middle value and limit.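

In the Mus musculus assay compound 1 gives > 99.7% as a limit of the assay and not a number. Within the data shown here, in the Mus musculus assay compound 4 gives > 99.8% as a limit of the assay and not a number, so no step between compound 1 and compound 4 can be read. The compounds shown leave open how far 4,5-dimethyl-1,3-thiazol-2-yl in place of 4-isopropyl-1,3-oxazol-2-yl changes plasma protein binding. In a physicochemical assay for solubility, measured as kinetic solubility, at pH 7.4 (on this read-out lower numbers stand for lower solubility and higher numbers for higher solubility), compound 1 gives 229000 nM and compound 4 gives 15000 nM, which makes a 15-fold lower number from compound 1 to compound 4 (1.18 log units; beyond the scatter) for the same exchange.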